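A Benzyl Amide Among Three Close Neighbours

The compounds below may be only part of what the source reports. "The series", "measured", "known", "first", "only" and "open" are said of these compounds alone.

In an ADME assay on HepG2 2.2.15 cells (Homo sapiens) for cytotoxicity, read by MTT assay, with stated times of 48 h and 9 days (a higher number here means that more compound is tolerated, a lower number that less compound is tolerated), three amides on a shared core lie close together. Compound 1 (`COc1ccc2c(=O)c(/C=C/C(=O)Nc3cccc(C)c3)coc2c1`) gives 554000 nM, compound 2 (`COc1ccc2c(=O)c(/C=C/C(=O)Nc3cccc(Cl)c3)coc2c1`) gives 1100000 nM, and compound 3 (`COc1ccc2c(=O)c(/C=C/C(=O)Nc3cc(C)ccc3C)coc2c1`) gives 1100000 nM. Compound 3 therefore stands level with compound 2 and within the scatter of compound 1. Compound 4 (`COc1ccc2c(=O)c(/C=C/C(=O)NCc3cccc(F)c3)coc2c1`) has 3-fluorobenzyl in place of 2,5-dimethylphenyl on an amide-type nitrogen.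

The closest evidence is the exchange of the group on that same nitrogen, which gave no change at the digits printed from compound 2 to compound 3 (within the scatter). The two smaller changes gave a 2.0-fold higher number from compound 1 to compound 2 (0.30 log units; within the scatter) and a 2.0-fold higher number from compound 1 to compound 3 (0.30 log units; within the scatter). None of the three measured compounds carries 3-fluorobenzyl, so these steps offer only indirect guidance, and the range must stay wide. They still give no reason to expect a shift beyond the scatter in this assay. The expected step is a 1.4-fold lower number from compound 3 to compound 4 (0.14 log units; within the scatter). For compound 4 the estimated value is 800000 nM, with an expected range of 300000 nM to 1800000 nM.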

Compound 4, half-maximal cytotoxic concentration: 475000 nM
For compound 4 the middle estimate is 1.7-fold (0.23 log units) above the measured one, within the range that was stated.
By their numbers in this assay, from the lowest: compounds 4, 1, 2 and 3 (each within the scatter of the next, the first and the last beyond it).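

Among the compounds shown here, on the amide-type nitrogen, 3-fluorobenzyl gives the only steps in this assay that pass the scatter so far, both modest (a 2.3-fold lower number from compound 3 to compound 4 (0.36 log units; beyond the scatter) and a 2.3-fold lower number from compound 2 to compound 4 (0.36 log units; beyond the scatter)), whereas the exchange among the three aryl groups on that nitrogen had stayed within it. Against 3-methylphenyl the same group gives a step within the scatter (a 1.2-fold lower number from compound 1 to compound 4 (0.07 log units; within the scatter)), so compound 1 goes against any general drop on moving to 3-fluorobenzyl at this position. Nothing measured here offers a cause for these steps.

Going by these compounds, whether the shift follows the benzyl group or its fluorine stays open, a question that plain benzyl or 3-fluorophenyl on the same nitrogen would address. On these data alone, how a longer chain such as 2-phenylethyl, or a benzyl group carrying a carboxylic acid, would read at this position also remains open.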